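Compound 3 to its ethyl ester: little change expected

A few compounds are considered here, and "the series" means these few. Any claim that something is new, unique, unknown or untested is made for them only; others in the source may bear on it.

Compound 1 `COc1cc(/C=C/C(=O)O)ccc1OC(=O)c1nc(C)c(C)nc1C`: 44600 nM
Compound 2 `CCOC(=O)/C=C/c1ccc(OC)cc1OC(=O)c1nc(C)c(C)nc1C`: 28200 nM
Compound 3 `Cc1nc(C)c(C(=O)Oc2ccc(/C=C/C(=O)O)cc2)nc1C`: 37800 nM

In a functional assay on a cell-free system (Platelet, plasma, Oryctolagus cuniculus) for inhibition, with a stated time of 5 min, at 37 degrees C (on this read-out lower numbers stand for stronger inhibition and higher numbers for weaker inhibition), compound 3 gives 37800 nM, which lies within the scatter of the values of both compound 1 and compound 2. The next compound is compound 4 `CCOC(=O)/C=C/c1ccc(OC(=O)c2nc(C)c(C)nc2C)cc1`, which has ethyl in place of hydrogen on an oxygen next to a carbonyl group, turning carboxy into ethoxycarbonyl: ethyl in place of hydrogen on an oxygen next to a carbonyl group.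

Among the compounds with values here, the only measured step between compounds that differ in one place is a 1.2-fold lower number from compound 1 to compound 3 (0.07 log units; within the scatter). It swaps hydrogen for methoxy, so it is a different change and lies within the scatter. Closer in kind, compound 2 carries the same ethoxycarbonyl and gives 28200 nM, while compound 1, with carboxy, gives 44600 nM. These two values lie within the scatter of each other, although the two compounds differ in more than one place.

No clear shift is therefore expected in this assay. The estimated change is a 1.3-fold lower number from compound 3 to compound 4 (0.10 log units; within the scatter), no step beyond the scatter. For compound 4 the expected value is 30000 nM, with an estimated range from 14000 nM to 62000 nM.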

Compound 4, half-maximal inhibitory concentration: 24400 nM
For compound 4 the middle estimate is 1.2-fold (0.09 log units) above the measured one; measured number inside the range.
By their numbers in this assay, from the lowest: compounds 4, 2, 3 and 1 (each within the scatter of the next).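

In this assay, within the data shown here, placing ethyl on the oxygen next to a carbonyl group gives a 1.5-fold lower number from compound 3 to compound 4 (0.19 log units; within the scatter), so this is the first measured single change at this position. Turning carboxy into ethoxycarbonyl leaves the two compounds within the scatter of each other, and the free hydrogen on this oxygen therefore shows no measurable role in this read-out for this pair. No measured evidence offers an explanation for this result.

As far as these compounds go, whether a longer chain, such as butyl, or a ring-bearing group, such as benzyl, would also stay within the scatter remains open. So does the outcome of replacing this oxygen with an amide nitrogen, and whether ethyl behaves the same way in the presence of a methoxy group on the aromatic ring.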